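Chain extension on the linker nitrogen in a shared tetrahydroisoquinoline-free core

This account rests on a few compounds, and the source may have more. Where it says the series, first, only, none or still open, it means among the compounds named here.

Measured compounds:
compound 1 `CCNC(=O)Nc1cccc2c1CN(C)CC2c1ccccc1`: 54 mg/kg
compound 2 `CCCCNC(=O)Nc1cccc2c1CN(C)CC2c1ccccc1`: 23 mg/kg
compound 3 `CCNCC(=O)Nc1cccc2c1CN(C)CC2c1ccc(Cl)cc1`: 6.4 mg/kg

All three were tested in a functional assay on the whole organism for inhibition, with Mus musculus as the target; a higher number here means that more compound is needed for the effect, a lower number that less compound is needed. Compound 1 and compound 2 share one core and differ in a single place: ethyl in place of hydrogen on a saturated chain carbon, two bonds along the chain from an amide-type nitrogen. That change gave a 2.3-fold lower number from compound 1 to compound 2 (0.37 log units; beyond the scatter).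

Compound 3 carries a different core; how it differs from compound 1 is not broken down here. In this assay compound 3 gives the lowest number of the three, with compound 2 reading higher and compound 1 higher still, both gaps beyond the scatter.

Compound 4 `CCCCNCC(=O)Nc1cccc2c1CN(C)CC2c1ccc(Cl)cc1` has not yet been measured. It differs from compound 3 by ethyl in place of hydrogen on a saturated chain carbon, two bonds along the chain from an amine nitrogen. Going by the values given here, this is the same kind of change as the step from compound 1 to compound 2, not the same change: there the entering ethyl sits two bonds along the chain from an amide-type nitrogen, here it sits two bonds along the chain from an amine nitrogen, and the core around it is the one of compound 3.

Among the compounds with values here, the expected step is a 2.0-fold lower number from compound 3 to compound 4 (0.30 log units; within the scatter), resting on the one earlier step of this kind, a 2.3-fold lower number from compound 1 to compound 2 (0.37 log units; beyond the scatter), with a widened range since the place and the core both differ. The expected value for compound 4 in this assay is 3.2 mg/kg, estimated to fall between 1.5 mg/kg and 7.5 mg/kg.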

Compound 4, dose for half-maximal effect: 3.9 mg/kg
Estimate against measurement, compound 4: 1.2-fold (0.09 log units) below; measured number inside the range.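

In this assay the change of ethyl in place of hydrogen on a saturated chain carbon, two bonds along the chain from an amine nitrogen, gives a 1.6-fold lower number from compound 3 to compound 4 (0.22 log units; within the scatter) and so cannot by itself be told apart from repeat scatter on this core. Set beside the earlier step on the other core, the two readings cannot be separated: the same change on two cores in this assay, a 2.3-fold lower number (0.37 log units; beyond the scatter) from compound 1 to compound 2 and a 1.6-fold lower number (0.22 log units; within the scatter) from compound 3 to compound 4, 1.4-fold (0.16 log units) apart, within the scatter of two such steps
The extension from ethylamino to butylamino therefore carries over from the core of compound 1 to the core of compound 3 with no detectable difference in the size of the step, but this rests on a single pair of steps, one of them within the scatter, and the entering ethyl sits two bonds from an amide-type nitrogen in one pair and from an amine nitrogen in the other, so it does not show that the change behaves the same way on other cores.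

Going by these compounds, whether a longer chain such as hexyl, a branched chain or a cyclic amine in place of butylamino would follow these two steps remains open. On these data alone, compound 1 and compound 3 differ in more than one place, so the separate contributions of the chloro group and the linker also remain open.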